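Methylpiperazine to methylpiperidine at the chain end

The source may hold more compounds than are shown below. What is called first, only, known or untested is meant among the compounds shown, and "the series" means these compounds.

Compound 1 `COc1cc2c(Oc3ccc(NS(=O)(=O)c4ccccc4C(F)(F)F)cc3F)ccnc2cc1OCCCN1CCN(C)CC1` gives 21 nM in an assay on isolated protein for inhibition of tyrosine-protein kinase receptor UFO (Homo sapiens) (a lower number here means a stronger inhibitor, a higher number a weaker inhibitor), the lowest of the two numbers recorded so far; compound 2 `COc1cc2c(Oc3ccc(NS(=O)(=O)c4ccccc4OC(F)(F)F)cc3F)ccnc2cc1OCCCN1CCN(C)CC1` gives 51 nM. Among the measured compounds shown here, the single measured step, a 2.4-fold higher number from compound 1 to compound 2 (0.39 log units; beyond the scatter), concerns a different part of the molecule and does not touch the chain end. Compound 3 `COc1cc2c(Oc3ccc(NS(=O)(=O)c4ccccc4C(F)(F)F)cc3F)ccnc2cc1OCCCN1CCC(C)CC1` carries 4-methylpiperidin-1-yl in place of 4-methylpiperazin-1-yl on a saturated chain carbon, three bonds along the chain from an oxygen on an aromatic ring. For the measured compounds named here, no measured step bears on this change, so no shift beyond the scatter is expected in this assay, with the range widened for lack of precedent. The expected value for compound 3 is 30 nM (range 10 nM to 90 nM), an expected step of a 1.4-fold higher number from compound 1 to compound 3 (0.15 log units; within the scatter).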

Compound 3, half-maximal inhibitory concentration: 27 nM
Estimate against measurement, compound 3: 1.1-fold (0.05 log units) above, within the range that was stated.
By their numbers in this assay, from the lowest: compounds 1, 3 and 2 (each within the scatter of the next, the first and the last beyond it).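

In this assay the chain end accepts 4-methylpiperidin-1-yl in place of 4-methylpiperazin-1-yl with a 1.3-fold higher number from compound 1 to compound 3 (0.11 log units; within the scatter) and no real difference between the two compounds. With the rest of compound 1 held fixed, the second ring nitrogen of 4-methylpiperazin-1-yl is therefore not needed to keep this number. No data at hand explain why the two groups read alike. Still open, going by these compounds, is whether a morpholine or a dimethylamino group at the chain end, or a chain longer than propyl, would read the same. Also open, on these data alone, is whether this swap holds alongside the trifluoromethoxy group of compound 2.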